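Methyl for Methoxy on a Thiocyanate-Bearing Core

The source may report more compounds than this note shows. Statements on the series, on what has been measured and on what is new or still open speak of the compounds shown alone.

Of the compounds shown here, three sharing a fused bicyclic core have been measured in a functional assay on L1210 cells (Mus musculus) for cytotoxicity, with a stated time of 48 h; on this read-out lower numbers stand for stronger inhibition and higher numbers for weaker inhibition. Compound 1 `COc1ccc(-c2nc3sc(Cc4ccc(Cl)cc4)nn3c2C=O)cc1` gives 5300 nM. Compound 2 `Cc1ccc(-c2nc3sc(Cc4ccc(Cl)cc4)nn3c2C=O)cc1` differs from it by methyl in place of methoxy on an aromatic carbon, and gives 23000 nM, a change of a 4.3-fold higher number from compound 1 to compound 2 (0.64 log units; beyond the scatter). Compound 3 `COc1ccc(-c2nc3sc(Cc4ccc(Cl)cc4)nn3c2SC#N)cc1` carries the same methoxy as compound 1 but its core differs by cyanosulfanyl in place of formyl on an aromatic carbon; in this assay compound 3 gives 16000 nM, a step of a 3.0-fold higher number from compound 1 to compound 3 (0.48 log units; beyond the scatter). Compound 2 and compound 3 lie within the scatter of each other.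

Compound 4 `Cc1ccc(-c2nc3sc(Cc4ccc(Cl)cc4)nn3c2SC#N)cc1` is not yet measured. It differs from compound 3 by methyl in place of methoxy on an aromatic carbon, the same change that separates compound 1 from compound 2, made here on the core that carries cyanosulfanyl rather than formyl. Among the compounds with values here, with only one earlier instance, the expected step from compound 3 to compound 4 is estimated as a 3.8-fold higher number from compound 3 to compound 4 (0.57 log units; beyond the scatter). Within the data shown here, this expectation rests on the earlier measured step of a 4.3-fold higher number from compound 1 to compound 2 (0.64 log units; beyond the scatter), which is the single example available. Compound 4 is therefore expected to give about 60000 nM in this assay, estimated to fall between 20000 nM and 180000 nM.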

Compound 4, half-maximal inhibitory concentration: 32000 nM
Beside the measured number, compound 4's estimate is 1.9-fold (0.27 log units) above it; the range from low to high includes it.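

In this assay, methyl in place of methoxy on the core carrying cyanosulfanyl gives a 2.0-fold higher number from compound 3 to compound 4 (0.30 log units; within the scatter), and this step does not differ measurably from the one on the core carrying formyl: the same change on two cores in this assay, a 4.3-fold higher number (0.64 log units; beyond the scatter) from compound 1 to compound 2 and a 2.0-fold higher number (0.30 log units; within the scatter) from compound 3 to compound 4, 2.2-fold (0.34 log units) apart, within the scatter of two such steps. Cyanosulfanyl in place of formyl, made with methyl rather than methoxy on the aromatic ring, gives a 1.4-fold higher number from compound 2 to compound 4 (0.14 log units; within the scatter), and this step likewise agrees with its earlier counterpart: the same change on two cores in this assay, a 3.0-fold higher number (0.48 log units; beyond the scatter) from compound 1 to compound 3 and a 1.4-fold higher number (0.14 log units; within the scatter) from compound 2 to compound 4, 2.2-fold (0.34 log units) apart, within the scatter of two such steps. Within the data shown here, the four compounds therefore give no sign that either change depends on the other, but with only one pair of steps for each change, they do not show that the methoxy-to-methyl step carries over at full size, nor that it vanishes on the second core.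

The compounds shown leave open whether an amine or ethoxy in place of methoxy would behave alike on both cores. They also leave open whether a carboxylic acid or an amide in place of formyl would fit the same picture.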